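The source may hold more compounds than are shown below. What is called first, only, known or untested is meant among the compounds shown, and "the series" means these compounds.

Compound 2 `O=C(NN1C(=O)CS[C@@H]1c1ccc(Cl)cc1)c1cnccn1` belongs to a small set of analogues built on a shared core and tested for cytotoxicity. In an ADME assay on A549 cells (Homo sapiens) for cytotoxicity, read by MTT assay, with a stated time of 3 days (a higher number here means a weaker inhibitor, a lower number a stronger inhibitor), compound 2 gives only a limit, > 100 ug/mL, and no number. Within the data shown here, the one other compound with a reading, compound 1 `Cc1cnc(C(=O)NN2C(=O)CS[C@@H]2c2ccc([N+](=O)[O-])cc2)cn1`, likewise returns a limit, > 100 ug/mL, in this assay. Both readings therefore rest at the limit of > 100 ug/mL in this assay, at which 2 of the 2 values shown sit. Among the measured compounds shown here, no measured step joins compound 1 and compound 2, as they differ in more than one place, so nothing beyond the fact that neither reaches a number can be drawn from them.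

Compound 3 `O=C(NN1C(=O)CS[C@@H]1c1ccc([N+](=O)[O-])cc1)c1cnccn1` has not yet been measured. It arises from compound 2 by the change (nitro in place of chloro on an aromatic carbon), nitro in place of chloro on an aromatic carbon. Compound 3 also carries the same nitro-bearing ring as compound 1, while lacking the methyl found on the core of compound 1.

For the measured compounds named here, no step between measured compounds covers this change. With both known values sitting at the limit, the step that the limit leaves unreadable from compound 2 to compound 3 is expected to be none beyond the scatter. Compound 3 is estimated at 150 ug/mL, within a range from 70 ug/mL to 400 ug/mL, and this assay is expected most likely to return only a limit again.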

Compound 3, half-maximal inhibitory concentration: > 100 ug/mL
Compound 3 ended at the assay's limit; the forecaster's own chance of this, stated with the estimate: 85%; the middle value is on the limit's open side.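

No step can be read from compound 1 or compound 2 to compound 3 in this assay because all three readings are limits and none is a number: the limit of > 100 ug/mL in this assay, at which 3 of the 3 values shown sit.

The compounds shown leave open whether any analogue on the shared core reaches a measurable value in this assay and how large the change from chloro to nitro would then be.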